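Compound 1 and the swap of methyl for phenyl

The source may hold more compounds than are shown below. What is called first, only, known or untested is meant among the compounds shown, and "the series" means these compounds.

In a functional assay on HT-29 cells (Homo sapiens) for cytotoxicity, read by MTT assay (a lower number here means a stronger inhibitor, a higher number a weaker inhibitor), the measured compounds stand as follows
- compound 1 `CC(=O)O[C@@H]1OC(=O)[C@](C)(C(C)=O)[C@@H]1C` gives 5000 nM
- compound 2 `CC(=O)O[C@@H]1OC(=O)[C@](Br)(C(C)=O)[C@@H]1C` gives 12000 nM

Compound 1 holds the lower of the two numbers. Compound 3 `CC(=O)[C@@]1(C)C(=O)O[C@@H](OC(=O)c2ccccc2)[C@H]1C` is still to be measured. Its change from compound 1 is phenyl in place of methyl on a carbonyl carbon or phenyl in place of methyl on a carbonyl carbon. Within the data shown here, the only measured step of a 2.4-fold higher number from compound 1 to compound 2 (0.38 log units; beyond the scatter) is modest and lies on a saturated ring carbon, not on a carbonyl carbon, so it gives no direction here. No step beyond the scatter is expected in this assay and the estimated step is a 1.3-fold lower number from compound 1 to compound 3 (0.10 log units; within the scatter) only. For compound 3 the estimate is 4000 nM with an expected range from 1500 nM to 15000 nM for now.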

Compound 3, half-maximal inhibitory concentration: 1000 nM
Compound 3: the middle estimate sits 4.0-fold (0.60 log units) above what was measured; the whole stated range lies above it.
By their numbers in this assay, from the lowest: compound 3; then compound 1; then compound 2.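

In this assay, phenyl in place of methyl on a carbonyl carbon gives a 5.0-fold lower number from compound 1 to compound 3 (0.70 log units; beyond the scatter). Among these compounds, this is the first step at this position, and it shows that one six-membered aromatic ring of carbon only is accepted there with a lower number, not a higher one. No measurement on hand accounts for the step.

On these data alone, whether the lower number depends on the aromatic ring or simply on the added carbons remains open. So does the outcome at this position for a cyclohexyl group, an amine or a longer chain.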